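From 2,6-dichlorophenyl to 2-fluoro-4-nitrophenyl

The source may report more compounds than this note shows. Statements on the series, on what has been measured and on what is new or still open speak of the compounds shown alone.

Compound 1 `CC(C)[C@H](NC(=O)COc1cccc2ccccc12)C(=O)N[C@@H](CC(=O)O)C(=O)COc1cccc(F)c1` gives 12000 nM
Compound 2 `CC(C)[C@H](NC(=O)COc1cccc2ccccc12)C(=O)N[C@@H](CC(=O)O)C(=O)COc1cc(F)cc(F)c1` gives 15900 nM
Compound 3 `CC(C)[C@H](NC(=O)COc1cccc2ccccc12)C(=O)N[C@@H](CC(=O)O)C(=O)COc1c(Cl)cccc1Cl` gives 15300 nM

These three values come from a functional assay with Homo sapiens as the target (a lower number here means a stronger inhibitor, a higher number a weaker inhibitor), and lie close together. Compound 3 sits within the scatter of both other compounds (a 1.3-fold higher number from compound 1 to compound 3 (0.11 log units; within the scatter)) (a 1.0-fold lower number from compound 2 to compound 3 (0.02 log units; within the scatter)). The next compound, compound 4 `CC(C)[C@H](NC(=O)COc1cccc2ccccc12)C(=O)N[C@@H](CC(=O)O)C(=O)COc1ccc([N+](=O)[O-])cc1F`, keeps the shared core and has 2-fluoro-4-nitrophenyl in place of 2,6-dichlorophenyl on an oxygen on a saturated carbon.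

The two steps above bear on this change, since both replace the same group. A third step, which adds one fluoro (a 1.3-fold higher number from compound 1 to compound 2 (0.12 log units; within the scatter)), also stayed within the scatter. Among these three compounds, then, changing this aromatic group has not moved the number measurably. None of them carries a nitro group, so the data offer no direct test of that addition, and the range must stay wide. No shift beyond the scatter is expected in this assay, and the estimated size of the change is small (a 1.1-fold lower number from compound 3 to compound 4 (0.04 log units; within the scatter)). The expected value for compound 4 is 14000 nM (estimated range 6000 nM to 30000 nM).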

Compound 4, half-maximal inhibitory concentration: 15800 nM
Compound 4: the middle estimate sits 1.1-fold (0.05 log units) below what was measured, within the range that was stated.
By their numbers in this assay, from the lowest: compounds 1, 3, 4 and 2 (each within the scatter of the next).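

Adding a nitro group, absent from the earlier compounds, gives no measurable shift in this assay: compound 4 stays within the scatter of all three earlier compounds (a 1.0-fold higher number from compound 3 to compound 4 (0.01 log units; within the scatter)) (a 1.0-fold lower number from compound 2 to compound 4 (0.00 log units; within the scatter)) (a 1.3-fold higher number from compound 1 to compound 4 (0.12 log units; within the scatter)). The aromatic group on an oxygen on a saturated carbon has now taken four forms, bearing chlorine, fluorine or nitro, without any step rising above the scatter. No supporting measurement is available to explain this flat result.

On these data alone, all four compounds keep a six-membered aromatic ring at this place, so it remains open whether a saturated cyclohexyl group or a small methyl group there would leave the number unchanged. As far as these compounds go, it is equally open whether an amine or a carboxylic acid on the aromatic ring would shift it.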